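Removing One Trifluoromethyl From the Aniline of Compound 1

This account rests on a few compounds, and the source may have more. Where it says the series, first, only, none or still open, it means among the compounds named here.

Of the compounds shown here, three of one series have been tested in a functional assay on HepG2 cells (Homo sapiens) for antiproliferative activity, read by spectrophotometry, with a stated time of 2 days; a higher number here means a weaker inhibitor of growth, a lower number a stronger inhibitor of growth. Within the data shown here, compound 1 `CN(c1cccc2c1CN(c1nc(Nc3cc(C(F)(F)F)cc(C(F)(F)F)c3)ncc1C(F)(F)F)C2)S(C)(=O)=O` is the only one with a number: in this assay compound 1 gives 10300 nM. Compound 2 `COc1ccc(C(F)(F)F)cc1Nc1ncc(C(F)(F)F)c(N2Cc3cccc(N(C)S(C)(=O)=O)c3C2)n1` reaches only a limit of this assay, > 30000 nM. Compound 3 `Cc1ccc(Nc2ncc(C(F)(F)F)c(N3Cc4cccc(N(C)S(C)(=O)=O)c4C3)n2)c(Cl)c1` likewise gives a limit, > 30000 nM. Among the measured compounds shown here, the single change between them, a step that the two limits leave unreadable from compound 2 to compound 3, therefore cannot be read. Compound 1 stands alone with a readable value, as shown by the limit of > 30000 nM in this assay, at which 2 of the 3 values shown sit.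

Compound 4 `CN(c1cccc2c1CN(c1nc(Nc3cccc(C(F)(F)F)c3)ncc1C(F)(F)F)C2)S(C)(=O)=O` differs from compound 1 in one place: hydrogen in place of trifluoromethyl on an aromatic carbon. For the measured compounds named here, no measured step covers this change, since the one measured step is unreadable. What can be said is that compound 1, carrying two trifluoromethyl groups on the aniline, gives 10300 nM. Compound 2 and compound 3, with other aniline substituents, each give only a limit of this assay. The expectation is therefore that loss of one trifluoromethyl will weaken growth inhibition or leave it within the scatter, rather than strengthen it. Compound 4 is estimated at 20000 nM, with a range from 6000 nM to 60000 nM. The step expected is a 1.9-fold higher number from compound 1 to compound 4 (0.29 log units; within the scatter).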

Compound 4, concentration for 50% growth inhibition: > 30000 nM
Compound 4 ended at the assay's limit; the forecaster's own chance of this, stated with the estimate: 40%; middle value at least 1.5-fold (0.17 log units) from the limit.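

Among these compounds, putting hydrogen in place of trifluoromethyl on this aromatic carbon gives an at least 2.9-fold higher number from compound 1 to compound 4 (0.46 log units; beyond the scatter), the first step that can be read, and it shows that growth inhibition in this assay does not survive the loss of this group. Going by these compounds, compound 4 gives > 30000 nM, which is a limit of the assay and not a number, so the true size of the step stays unknown and it may be larger than printed. The steps among compound 2, compound 3 and compound 4 cannot be read, and compound 1 remains the only compound with a number, which leaves little room for comparison in this series: the limit of > 30000 nM in this assay, at which 3 of the 4 values shown sit.

The compounds shown leave open whether a different group on this aromatic carbon, such as a nitrile or an amine, would match compound 1 or move growth inhibition to a clearly lower number. They also leave open what changes elsewhere on the shared core would do, since every change shown here lies on the aniline ring.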